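The source may report more compounds than this note shows. Statements on the series, on what has been measured and on what is new or still open speak of the compounds shown alone.

Among the compounds with values here, in an ADME assay on Vero 76 cells (Chlorocebus sabaeus) for cytotoxicity, read by crystal violet staining, with a stated time of 96 h (a higher number here means that more compound is tolerated, a lower number that less compound is tolerated), compound 1 `FC(F)(F)c1cccc(NC(=S)Nc2ccc(I)cc2)c1` gives 9500 nM and stands lowest of the two numbers so far, with compound 2 `Cc1ccc(NC(=S)Nc2cccc(C(F)(F)F)c2)cc1Cl` at 20000 nM and the gap beyond the scatter. Compound 3 `FC(F)(F)c1cccc(NC(=S)Nc2ccccc2)c1` departs from compound 1 by hydrogen in place of iodo on an aromatic carbon in one place: hydrogen in place of iodo on an aromatic carbon, para to a large group. Within the data shown here, no measured pair shows this change, so the expectation is a loose one. A modest rise is expected, an estimated 2.5-fold higher number from compound 1 to compound 3 (0.40 log units; beyond the scatter) with more compound tolerated. For compound 3 the estimated value is 24000 nM with 9000 nM to 70000 nM as its expected range.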

Compound 3, half-maximal cytotoxic concentration: 39000 nM
Compound 3: middle estimate off by 1.6-fold (0.21 log units), on the low side; the range from low to high includes it.
By their numbers in this assay, from the lowest: compound 1; then compounds 2 and 3 (each within the scatter of the next).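

In this assay, within the data shown here, this is the first step that isolates this position: with hydrogen in place of iodo on an aromatic carbon, para to a large group, the shared core shows a 4.1-fold higher number from compound 1 to compound 3 (0.61 log units; beyond the scatter). Going from 4-iodophenyl to phenyl therefore raises the tolerated concentration, so the iodo group on this carbon matters to the read-out. Nothing at hand accounts for the size of this step. The compounds shown leave open what an amine, a hydroxyl or a carboxylic acid on this carbon would do. They also leave open whether the step would hold on another core.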